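The source may report more compounds than this note shows. Statements on the series, on what has been measured and on what is new or still open speak of the compounds shown alone.

Compound 1 `Clc1ccccc1Cn1nnc2c(NC3CCCC3)ncnc21` is the reference point of this small set. In an assay on cell membranes for binding affinity to adenosine receptor A1 (Bos taurus), read by radioligand binding (on this read-out lower numbers stand for stronger inhibition and higher numbers for weaker inhibition), compound 1 gives 21 nM. Among the compounds with values here, compound 2 `Clc1ccccc1Cn1nnc2c(NCC3CCCCC3)ncnc21` shares its core and its 2-chlorobenzyl group, and in this assay compound 2 gives 4260 nM; the single measured step, a 200-fold higher number from compound 1 to compound 2 (2.31 log units; beyond the scatter), shows how strongly the group on the amine nitrogen alone can move the number. Compound 3 `O=[N+]([O-])c1cccc(Nc2ncnc3c2nnn3Cc2ccccc2)c1` carries a 3-nitrophenyl group on that nitrogen and a plain benzyl group on the other ring nitrogen; in this assay compound 3 gives 443 nM, which places it second highest of the three numbers, nearer to compound 2 than to compound 1.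

Compound 4 `O=[N+]([O-])c1cccc(Nc2ncnc3c2nnn3Cc2ccccc2Cl)c1` differs from compound 3 in one place: chloro in place of hydrogen on an aromatic carbon, on an aromatic carbon of a six-membered aromatic ring of carbon only, so that the benzyl group becomes a 2-chlorobenzyl group. Within the data shown here, no measured step here isolates that change; compounds 1 and 2 both carry the 2-chlorobenzyl group, but they differ from each other elsewhere, so they cannot be compared to compound 3 directly. A small change is therefore expected, estimated as a 1.5-fold lower number from compound 3 to compound 4 (0.17 log units; within the scatter). Compound 4 is expected to give about 300 nM in this assay, within a range of 90 nM to 1000 nM.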

Compound 4, inhibition constant: 3300 nM
For compound 4 the middle estimate is 11-fold (1.04 log units) below the measured one, and the stated range ends below it.
By their numbers in this assay, from the lowest: compound 1; then compound 3; then compounds 4 and 2 (each within the scatter of the next).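

In this assay, within the data shown here, a single chloro on an aromatic carbon of the benzyl group, ortho to a large group, gives a 7.4-fold higher number from compound 3 to compound 4 (0.87 log units; beyond the scatter) and so provides the first direct reading of this position: with 3-nitrophenyl on the amine nitrogen, the 2-chlorobenzyl group gives weaker binding than the plain benzyl group. With the 2-chlorobenzyl group held fixed, the group on the amine nitrogen can now be compared at a third point: 3-nitrophenyl in place of cyclopentyl gives a 160-fold higher number from compound 1 to compound 4 (2.20 log units; beyond the scatter) and joins cyclohexylmethyl at the weak end of the set, while the step of a 1.3-fold lower number from compound 2 to compound 4 (0.11 log units; within the scatter) does not separate 3-nitrophenyl from cyclohexylmethyl. Nothing available here explains why the chloro or either change on the nitrogen moves the number.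

The compounds shown leave open whether the chloro would shift the number in the same direction and by a similar amount with cyclopentyl or cyclohexylmethyl on the amine nitrogen. They also leave open how a fluoro, a methyl or a methoxy group would read at the same place on the benzyl group.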